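Swapping the dichlorophenyl for plain phenyl on a shared core

The source may report more compounds than this note shows. Statements on the series, on what has been measured and on what is new or still open speak of the compounds shown alone.

Three compounds share one core and differ only in the group attached to one aromatic carbon. Compound 1 `O=C(Oc1ccc([N+](=O)[O-])cc1)N1CCN(S(=O)(=O)c2ccc(C3CCCCC3)cc2)CC1` gives 333 nM in an assay on isolated protein for inhibition of Fatty-acid amide hydrolase 1 (Homo sapiens), read by fluorescence; a higher number here means a weaker inhibitor, a lower number a stronger inhibitor. Compound 2 `O=C(Oc1ccc([N+](=O)[O-])cc1)N1CCN(S(=O)(=O)c2ccc(Oc3ccccc3)cc2)CC1` gives 322 nM in this assay. Compound 3 `O=C(Oc1ccc([N+](=O)[O-])cc1)N1CCN(S(=O)(=O)c2ccc(-c3ccc(Cl)c(Cl)c3)cc2)CC1` gives 382 nM in this assay; its number is the highest of the three, yet both steps to it fall within the scatter: a 1.1-fold higher number from compound 1 to compound 3 (0.06 log units; within the scatter) and a 1.2-fold higher number from compound 2 to compound 3 (0.07 log units; within the scatter). The remaining step, a 1.0-fold lower number from compound 1 to compound 2 (0.01 log units; within the scatter), is equally small. Compound 4 `O=C(Oc1ccc([N+](=O)[O-])cc1)N1CCN(S(=O)(=O)c2ccc(-c3ccccc3)cc2)CC1` carries phenyl in place of 3,4-dichlorophenyl on an aromatic carbon. For the measured compounds named here, since every exchange at this position so far moved the number within the scatter, no step beyond the scatter is expected here either. Compound 4 is therefore expected to give about 350 nM, within 150 nM to 800 nM, meaning a 1.1-fold lower number from compound 3 to compound 4 (0.04 log units; within the scatter).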

Compound 4, half-maximal inhibitory concentration: 437 nM
For compound 4 the middle estimate is 1.2-fold (0.10 log units) below the measured one, within the range that was stated.
By their numbers in this assay, from the lowest: compounds 2, 1, 3 and 4 (each within the scatter of the next).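

Phenyl in place of 3,4-dichlorophenyl takes away both chlorine atoms yet gives only a 1.1-fold higher number from compound 3 to compound 4 (0.06 log units; within the scatter) in this assay, so the two chlorines make no readable difference here. Plain phenyl also shows a 1.4-fold higher number from compound 2 to compound 4 (0.13 log units; within the scatter) and a 1.3-fold higher number from compound 1 to compound 4 (0.12 log units; within the scatter) in this assay, which means all four groups at this position remain indistinguishable. Nothing available explains this flat result. From the compounds shown here alone, whether an amine or a carboxylic acid at this position would also stay within the scatter remains open.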